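The source may hold more compounds than are shown below. What is called first, only, known or untested is meant among the compounds shown, and "the series" means these compounds.

The series rests on a shared core, carried by compound 1 `CC1CCN(CC(=O)O[C@@H]2C[C@@H]3CC[C@@]2(C)C3(C)C)CC1` and compound 2 `CC1CCN(CCCCC(=O)O[C@@H]2C[C@@H]3CC[C@@]2(C)C3(C)C)CC1`. In an ADME assay on HEK-293T cells (Homo sapiens) for cytotoxicity, read by MTT assay, with a stated time of 48 h (a lower number here means that less compound is tolerated, a higher number that more compound is tolerated), compound 1 gives 71600 nM, and in this assay compound 2 gives 73000 nM. Among the two numbers shown, compound 2 stands alongside compound 1, its only neighbour, with the two values within the scatter of each other, so no difference between them can be read. Compound 3 `CC1(C)[C@H]2CC[C@]1(C)[C@H](OC(=O)CCCN1CCCCCC1)C2` has not yet been measured. It differs from compound 2 in one place: azepan-1-yl in place of (4-methylpiperidin-1-yl)methyl on a saturated chain carbon, three bonds along the chain from a carbonyl carbon. Going by the values given here, no step between measured compounds is available to guide the estimate, and the two measured values lie within the scatter of each other. The step expected in this assay, a 1.0-fold lower number from compound 2 to compound 3 (0.02 log units; within the scatter), is therefore none beyond the scatter. Compound 3 is estimated at 70000 nM, with a range from 35000 nM to 140000 nM.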

Compound 3, half-maximal cytotoxic concentration: 62200 nM
Beside the measured number, compound 3's estimate is 1.1-fold (0.05 log units) above it; the measured number falls inside the stated range.
By their numbers in this assay, from the lowest: compounds 3, 1 and 2 (each within the scatter of the next).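

In this assay, exchanging the (4-methylpiperidin-1-yl)methyl group for azepan-1-yl gives a 1.2-fold lower number from compound 2 to compound 3 (0.07 log units; within the scatter). Going by these compounds alone, this is the first step between measured compounds that differ in one place. It shows that, in this read-out, a seven-membered non-aromatic ring at this position cannot be told apart from the six-membered ring it replaces. Nothing at hand explains this result.

Going by these compounds, one step at one position sets no trend, so it remains open whether morpholin-4-yl or an open-chain amine such as diethylamino on this chain carbon would also stay within the scatter of compound 2. Equally open, on these data alone, is what an amide in place of the ester link would do to the number.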